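Swapping a Methylphenyl Ring for a Dimethylpyridyl Ring

A few compounds are considered here, and "the series" means these few. Any claim that something is new, unique, unknown or untested is made for them only; others in the source may bear on it.

Measured so far:
Compound 1 `Cc1ccc(-c2c(C)nn(-c3nc(-c4ccc(Cl)c(Cl)c4)c(SC(C)C)s3)c2C(=O)O)cc1`: 3800 nM
Compound 2 `Cc1nn(-c2nc(-c3ccc(Cl)c(Cl)c3)c(SC(C)C)s2)c(C(=O)O)c1-c1cncnc1`: 22000 nM
Compound 3 `Cc1cccc(-c2c(C)nn(-c3nc(-c4ccc(Cl)c(Cl)c4)c(SC(C)C)s3)c2C(=O)O)c1`: 17000 nM

In a functional assay on BJAB cells (Homo sapiens) for antiproliferative activity, with a stated time of 4 days (a higher number here means that more compound is needed for the effect, a lower number that less compound is needed), compound 3 holds the second highest of the three numbers: the gap is a 4.5-fold higher number from compound 1 to compound 3 (0.65 log units; beyond the scatter), whereas compound 2 sits close, as a 1.3-fold lower number from compound 2 to compound 3 (0.11 log units; within the scatter) shows. Compound 4 `Cc1cc(-c2c(C)nn(-c3nc(-c4ccc(Cl)c(Cl)c4)c(SC(C)C)s3)c2C(=O)O)cc(C)n1` is not yet measured; it differs from compound 3 by one change: 2,6-dimethylpyridin-4-yl in place of 3-methylphenyl on an aromatic carbon. For the measured compounds named here, two steps bear on this. The step of a 5.8-fold higher number from compound 1 to compound 2 (0.76 log units; beyond the scatter) shows that a nitrogen-containing six-membered ring in this position raised the number, but the step of a 1.3-fold lower number from compound 2 to compound 3 (0.11 log units; within the scatter) shows that compound 2 and compound 3 lie within the scatter of each other. Compound 4 is therefore expected to change little from compound 3, a step of no change at the digits printed from compound 3 to compound 4 (within the scatter) within the scatter. The estimate for compound 4 is 17000 nM, in the range 6000 nM to 50000 nM.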

Compound 4, half-maximal effective concentration: 580 nM
Compound 4: middle estimate off by 29-fold (1.47 log units), on the high side; measured number outside the range, below it.
By their numbers in this assay, from the lowest: compound 4; then compound 1; then compounds 3 and 2 (each within the scatter of the next).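

In this assay, for the compounds shown here, the ring on this aromatic carbon can matter far more than the earlier compounds showed: the steps of a 29-fold lower number from compound 3 to compound 4 (1.47 log units; beyond the scatter) and a 38-fold lower number from compound 2 to compound 4 (1.58 log units; beyond the scatter) mean that a ring containing nitrogen need not raise the number. The 2,6-dimethylpyridin-4-yl group also goes beyond the 4-methylphenyl ring, with a 6.6-fold lower number from compound 1 to compound 4 (0.82 log units; beyond the scatter) as the step. No measurement given here explains this drop.

Going by these compounds, it remains open whether the ring nitrogen, the two methyl groups or their combination matters. A pyridin-4-yl ring without methyl groups, or one bearing an amine, would help separate these.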